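Exchanging one phenyl group for another

The compounds below may be only part of what the source reports. "The series", "measured", "known", "first", "only" and "open" are said of these compounds alone.

In an ADME assay on HepG2 cells (Homo sapiens) for cytotoxicity (a higher number here means that more compound is needed for the effect, a lower number that less compound is needed), compound 3 `Cc1ccc(S(=O)(=O)N[C@@H](CC(=O)NC(C)(C)C)C(=O)NCCNC(=O)c2c(O)cccc2F)cc1` gives > 11000 nM, which is a limit of the assay. Compound 1 `Cc1ccc(S(=O)(=O)N[C@@H](CC(=O)NC(C)(C)C)C(=O)NCCNC(=O)c2cc(Cl)ccn2)cc1` gives > 11000 nM, which is also a limit. Compound 2 `Cc1ccc(S(=O)(=O)N[C@@H](CC(=O)NC(C)(C)C)C(=O)NCCNC(=O)c2cccc(C(C)C)c2)cc1` gives > 11000 nM, again a limit. Compound 3 therefore has no number of its own, and its standing is summed up as the limit of > 11000 nM in this assay, at which 3 of the 3 values shown sit.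

Compound 4 `COc1cccc(C(=O)NCCNC(=O)[C@H](CC(=O)NC(C)(C)C)NS(=O)(=O)c2ccc(C)cc2)c1` carries 3-methoxyphenyl in place of 2-fluoro-6-hydroxyphenyl on a carbonyl carbon.

Three measured changes at this same place bear on it: a step that the two limits leave unreadable from compound 1 to compound 2, a step that the two limits leave unreadable from compound 1 to compound 3 and a step that the two limits leave unreadable from compound 2 to compound 3. None of them has a readable size, so no number can be carried over, but all three compounds ended at the same limit. No shift beyond the usual scatter is therefore expected, and no direction can be foreseen. The expected step is a step that the limit leaves unreadable from compound 3 to compound 4.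

For compound 4 the estimate is 15000 nM, with an expected range from 8000 nM to 30000 nM.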

Compound 4, half-maximal effective concentration: > 11000 nM
Compound 4 gave a limit, no number (the forecaster's own chance of this, stated with the estimate: 90%); the middle value does not contradict the limit.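

Compound 4 gives > 11000 nM, which is a limit of the assay, so its steps from compound 1, compound 2 and compound 3 cannot be read. How much of any of these compounds is needed for the effect in this assay, and whether exchanging this group changes that amount, stays open because all of them stop at the same point: the limit of > 11000 nM in this assay, at which 4 of the 4 values shown sit.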